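The compounds below may be only part of what the source reports. "The series", "measured", "known", "first", "only" and "open" are said of these compounds alone.

Compound 1, `O=C(OCc1ccccc1)N1CCN(C(=S)SCc2cn(Cc3ccc(Cl)cc3)nn2)CC1`, was tested in a functional assay on PC-3 cells (Homo sapiens) for inhibition, read by MTT assay, with a stated time of 72 h; on this read-out higher numbers stand for weaker inhibition and lower numbers for stronger inhibition. In this assay compound 1 gives only a limit, > 128000 nM, so no number is known for it. Two other compounds share its core and differ from it only at the ring nitrogen that carries the benzyloxycarbonyl group. Compound 2, `CC(C)(C)OC(=O)N1CCN(C(=S)SCc2cn(Cc3ccc(Cl)cc3)nn2)CC1`, also gives only a limit in this assay, > 128000 nM. Compound 3, `S=C(SCc1cn(Cc2ccc(Cl)cc2)nn1)N1CCNCC1`, likewise gives only a limit, > 128000 nM. The steps among these three cannot be read, a step that the two limits leave unreadable from compound 1 to compound 2, a step that the two limits leave unreadable from compound 1 to compound 3 and a step that the two limits leave unreadable from compound 2 to compound 3, because of the limit of > 128000 nM in this assay, at which 3 of the 3 values shown sit.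

Compound 4, `O=C(OCc1ccccc1)N1CCN(C(=S)SCc2cn(Cc3ccccc3Cl)nn2)CC1`, has the same atoms as compound 1, joined differently: 2-chlorophenyl in place of 4-chlorophenyl on a saturated chain carbon bound to an aromatic nitrogen. Going by the values given here, none of the measured steps touches the chlorophenyl group, so they give no guide to the size or direction of this change; they show only that every compound measured so far sits at the limit of this assay. The expectation is therefore that compound 4 also sits at that limit, and the expected step is a number no higher from compound 1 to compound 4 (the limit leaves the size open), which is not expected to be readable. Compound 4 is estimated at 128000 nM, within a range from 30000 nM to 500000 nM.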

Compound 4, half-maximal inhibitory concentration: > 128000 nM
Compound 4: only a limit was reported (the forecaster's own chance of this, stated with the estimate: 80%); the middle value lies on the limit itself.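

In this assay compound 4 gives only a limit, > 128000 nM, so no new step can be read between compound 1 and compound 4: the limit of > 128000 nM in this assay, at which 4 of the 4 values shown sit. The compounds shown leave open whether moving the chlorine from 4-chlorophenyl to 2-chlorophenyl changes inhibition at all, as none of them gives an actual number in this assay.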